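The compounds below may be only part of what the source reports. "The series", "measured", "known", "first", "only" and "open" are said of these compounds alone.

Measured so far in a functional assay on SH-SY5Y cells (Homo sapiens) for cytotoxicity, read by MTT assay, with stated times of 24 h and 4 h; on this read-out lower numbers stand for an effect already at smaller amounts and higher numbers for an effect only at larger amounts of compound:
Compound 1 `COc1cc(CNC(=O)/C=C/c2ccccc2)ccc1OCc1nc(C)c(C)nc1C` gives 7310 nM.
Compound 2 `COc1cccc(/C=C/C(=O)NCc2ccc(OCc3nc(C)c(C)nc3C)c(OC)c2)c1` gives 4320 nM.
Compound 3 `COc1cc(/C=C/C(=O)NCc2ccc(OCc3nc(C)c(C)nc3C)c(OC)c2)cc(OC)c1` gives 8660 nM.

All three share one core and differ only in the ring at the end of the double-bonded chain. Compound 3 has the highest number of the three, but its steps to the others are small: a 2.0-fold higher number from compound 2 to compound 3 (0.30 log units; within the scatter) and a 1.2-fold higher number from compound 1 to compound 3 (0.07 log units; within the scatter). Within this set, then, no compound can be set apart from the others on this read-out.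

Compound 4 `COc1cc(CNC(=O)/C=C/c2ccc(OC)c(OC)c2OC)ccc1OCc1nc(C)c(C)nc1C` is the next one to be tested. The change from compound 3 is 2,3,4-trimethoxyphenyl in place of 3,5-dimethoxyphenyl on a double-bonded chain carbon bound to a double-bonded chain carbon. Among the compounds with values here, the steps that bear on it are those that altered the same ring: adding methoxy groups to it gave a 1.7-fold lower number from compound 1 to compound 2 (0.23 log units; within the scatter) and a 2.0-fold higher number from compound 2 to compound 3 (0.30 log units; within the scatter), and exchanging the bare ring for the dimethoxy one gave a 1.2-fold higher number from compound 1 to compound 3 (0.07 log units; within the scatter). None of these moved the number beyond the scatter. Compound 4 again changes only the methoxy pattern on that ring, so no step beyond the scatter is expected in this assay. The expected step for compound 4 is a 1.1-fold lower number from compound 3 to compound 4 (0.03 log units; within the scatter). Compound 4 is therefore estimated at 8000 nM, with a range from 3500 nM to 18000 nM.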

Compound 4, half-maximal effective concentration: 3840 nM
For compound 4 the middle estimate is 2.1-fold (0.32 log units) above the measured one, and the stated range covers the measured number.
By their numbers in this assay, from the lowest: compounds 4, 2, 1 and 3 (each within the scatter of the next, the first and the last beyond it).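

In this assay, the ring on the double-bonded chain carbon now shows its first change beyond the scatter: 2,3,4-trimethoxyphenyl in place of 3,5-dimethoxyphenyl gives a 2.3-fold lower number from compound 3 to compound 4 (0.35 log units; beyond the scatter), a modest step. The same ring compared with 3-methoxyphenyl gives a 1.1-fold lower number from compound 2 to compound 4 (0.05 log units; within the scatter), and compared with phenyl it gives a 1.9-fold lower number from compound 1 to compound 4 (0.28 log units; within the scatter), so only the comparison with 3,5-dimethoxyphenyl separates the two compounds, and these four compounds show no steady link between the number of methoxy groups and the read-out. Nothing available here explains why this one pair stands apart.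

From the compounds shown here alone, all four compounds carry only hydrogen or methoxy groups on this ring, so the effect of an amine, a carboxylic acid or a chlorine atom on it remains open. Also open, going by these compounds, is whether a longer chain in place of a methoxy group would give a step beyond the scatter, and whether the modest step seen here would extend to ring patterns beyond these four.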